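This account rests on a few compounds, and the source may have more. Where it says the series, first, only, none or still open, it means among the compounds named here.

The study measured three compounds on a shared core in an ADME assay on Vero cells (Chlorocebus sabaeus) for cytotoxicity, read by MTT assay, with a stated time of 72 h; on this read-out higher numbers stand for lower toxicity in this test and lower numbers for higher toxicity in this test. Compound 1 `CSCC(=O)N1CCN(c2nc(=O)c3cc(C(F)(F)F)cc([N+](=O)[O-])c3s2)CC1` gives > 125000 nM there, which is a limit of the assay and not a number. Compound 2 `O=C(c1ccc(Cl)cc1)N1CCN(c2nc(=O)c3cc(C(F)(F)F)cc([N+](=O)[O-])c3s2)CC1` gives > 125000 nM in this assay, again a limit and not a number. Among the compounds with values here, compound 3 `O=C(C1CCCC1)N1CCN(c2nc(=O)c3cc(C(F)(F)F)cc([N+](=O)[O-])c3s2)CC1` gives 120000 nM in this assay, the only plain number among the three. Compound 2 thus stands at the limit, as the limit of > 125000 nM in this assay, at which 2 of the 3 values shown sit, records. The step that the two limits leave unreadable from compound 1 to compound 2 cannot be read, while the steps of an at least 1.0-fold lower number from compound 1 to compound 3 (0.01 log units; that floor lies within the scatter) and an at least 1.0-fold lower number from compound 2 to compound 3 (0.01 log units; that floor lies within the scatter) both lie within the scatter, so nothing measured so far separates any two of these compounds.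

Compound 4 `O=C(c1ccc(F)cc1)N1CCN(c2nc(=O)c3cc(C(F)(F)F)cc([N+](=O)[O-])c3s2)CC1` has not yet been measured in this assay. It differs from compound 2 by fluoro in place of chloro on an aromatic carbon. Within the data shown here, no measured step exchanges one halogen for another; the steps that exist replace the whole group on the carbonyl carbon and show nothing beyond the scatter. Compound 4 is therefore expected to remain within the scatter of compound 2 in this assay. The step of a number no higher from compound 2 to compound 4 (the limit leaves the size open) is the size expected. Compound 4 is estimated at 125000 nM, between 60000 nM and 250000 nM, and most likely reported once more as a limit.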

Compound 4, half-maximal cytotoxic concentration: > 125000 nM
Compound 4 was reported as a limit (the forecaster's own chance of this, stated with the estimate: 70%); the middle value lies on the limit itself.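

Fluoro in place of chloro on the aromatic carbon, para to a large group, leaves compound 4 at the same recorded limit as compound 2, so both halogens at this position now end at one record in this assay: the limit of > 125000 nM in this assay, at which 3 of the 4 values shown sit. The exchange of one halogen for the other cannot be read, and neither can the step between compound 1 and compound 4, as each pair has a limit at both ends. Within the data shown here, the one step that can be read, an at least 1.0-fold higher number from compound 3 to compound 4 (0.01 log units; that floor lies within the scatter), separates the 4-fluorophenyl group from cyclopentyl no more clearly than the earlier step separated 4-chlorophenyl from cyclopentyl.

The compounds shown leave open how far the true values of compound 1, compound 2 and compound 4 lie from one another, and whether any change at these two places moves the number beyond the scatter. As far as these compounds go, it also remains open what an amine or a carboxylic acid at this position on the aromatic ring, or a longer chain on the carbonyl carbon, would give in this assay.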